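Sulfonate esters on breast cancer cells: swapping isopropyl for iodo

A few compounds are considered here, and "the series" means these few. Any claim that something is new, unique, unknown or untested is made for them only; others in the source may bear on it.

Two related sulfonate esters have been tested so far. Compound 1 `CC(C)C(=O)Nc1cccc(S(=O)(=O)Oc2ccccc2C(C)C)c1` carries a branched amide and, in a functional assay on MCF7 cells (Homo sapiens) for antiproliferative activity, read by sulforhodamine B assay, with a stated time of 48 h (on this read-out higher numbers stand for weaker inhibition and lower numbers for stronger inhibition), compound 1 gives 13000 nM. Compound 2 `CC(=O)Nc1ccc(S(=O)(=O)Oc2ccccc2C(C)C)cc1` carries a smaller amide on a differently arranged ring, and in this assay compound 2 gives 16000 nM. On these two numbers compound 2 has the highest value, yet its nearest neighbour, compound 1, differs from it by an amount that falls within the usual scatter of this kind of measurement, so the two compounds cannot be told apart on potency. Compound 1 and compound 2 differ in more than one place. Among the measured compounds shown here, no single step connects them.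

Compound 3 `CC(=O)Nc1ccc(S(=O)(=O)Oc2ccccc2I)cc1` is the next compound to be measured. It differs from compound 2 in one place only: iodo in place of isopropyl on an aromatic carbon. For the measured compounds named here, no measured pair shows what such a swap does here, so the expectation rests on the size of the groups alone, which are broadly alike. The step from a 1.1-fold lower number from compound 2 to compound 3 (0.03 log units; within the scatter) is expected to stay within the scatter, in no particular direction. For compound 3 the estimated value in this assay is 15000 nM, with a likely range from 5000 nM to 45000 nM.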

Compound 3, half-maximal inhibitory concentration: 27000 nM
Estimate against measurement, compound 3: 1.8-fold (0.26 log units) below; the measured number falls inside the stated range.
By their numbers in this assay, from the lowest: compounds 1, 2 and 3 (each within the scatter of the next, the first and the last beyond it).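

In this assay, among the compounds shown here, this is the first direct test of this position, and the swap of iodo for isopropyl gives a 1.7-fold higher number from compound 2 to compound 3 (0.23 log units; within the scatter). On this evidence, compound 2 and compound 3 cannot be told apart, even though a single iodine atom has taken the place of a group of 3 carbon atoms on an aromatic carbon ortho to a large group, so this one change in group size leaves no effect that can be separated from ordinary measurement scatter. For the compounds shown here, nothing measured so far bears on why these two groups read alike.

This single pair leaves open whether the position would stay just as indifferent to groups of a different kind, such as an amine, a carboxylic acid or a longer chain, or to a bare hydrogen. It also leaves open whether iodo in place of isopropyl would read the same way on the core of compound 1, with its branched amide and differently arranged ring.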